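Swapping Ethyl for Vinyl on a Sugar-Like Ring

The source may report more compounds than this note shows. Statements on the series, on what has been measured and on what is new or still open speak of the compounds shown alone.

Compound 1 `CC[C@@]1(O)[C@@H](CO)O[C@@H](n2ccc(N)nc2=O)[C@@H]1O` was tested in a functional assay on L1210 cells (Mus musculus), read by MTT assay (on this read-out higher numbers stand for weaker inhibition and lower numbers for stronger inhibition), where compound 1 gives 269000 nM. Compound 2 `CCC#C[C@@]1(O)[C@@H](CO)O[C@@H](n2ccc(=O)[nH]c2=O)[C@@H]1O` sits close by: in this assay compound 2 gives 338000 nM, and the gap between the two lies within the usual scatter, so they cannot be told apart. Compound 3 `C#C[C@H]1[C@@H](O)[C@H](n2ccc(=O)[nH]c2=O)O[C@@H]1CO` reaches only a limit of the assay, (the limit of > 350000 nM in this assay, at which 1 of the 3 values shown sits), and in this assay compound 3 gives > 350000 nM. Of the two actual numbers, compound 1 stands at the lower one, a position that the scatter does not make meaningful.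

Compound 4 `C=C[C@@]1(O)[C@@H](CO)O[C@@H](n2ccc(N)nc2=O)[C@@H]1O` differs from compound 1 in one place: vinyl in place of ethyl on a saturated ring carbon. For the measured compounds named here, no measured pair shows a change of this kind, so there is nothing to lean on. The expected step from compound 1 to compound 4 , a 1.0-fold lower number from compound 1 to compound 4 (0.01 log units; within the scatter), is estimated to stay within the scatter, with no clear direction. Compound 4 is therefore expected to give about 260000 nM in this assay, between 90000 nM and 700000 nM.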

Compound 4, half-maximal inhibitory concentration: 60800 nM
The estimate for compound 4 lay 4.3-fold (0.63 log units) above the measured number; measured number below the stated range.
By their numbers in this assay, from the lowest: compound 4; then compounds 1 and 2 (each within the scatter of the next). At a limit, above all of these: compound 3.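

Before this pair, no two measured compounds differed in one place, so this is the first reading of what this saturated ring carbon tolerates. In this assay, vinyl in place of ethyl gives a 4.4-fold lower number from compound 1 to compound 4 (0.65 log units; beyond the scatter), a modest step but one beyond the scatter, which shows that the number responds at this position even though the two groups have the same count of heavy atoms and differ in the double bond. Nothing given here explains why this swap lowers the number.

Still open, on these data alone, is how other groups on this carbon would behave, such as a propyl chain, an amine or a carboxylic acid. It is also unknown whether the same swap would give a similar step on a different core.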